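Ring-Nitrogen Substituent Series: Cyclopentyl to Cyclohexylmethyl

This account rests on a few compounds, and the source may have more. Where it says the series, first, only, none or still open, it means among the compounds named here.

Measured compounds:
compound 1 `CCC(CC)n1c(-c2ccc(OCc3c(-c4c(Cl)cccc4Cl)noc3C(C)C)cc2F)nc2ccc(C(=O)O)cc21` — 1.3 nM
compound 2 `CC(C)c1onc(-c2c(Cl)cccc2Cl)c1COc1ccc(-c2nc3ccc(C(=O)O)cc3n2C2CCCC2)cc1` — 13.6 nM
compound 3 `CC(C)c1onc(-c2c(Cl)cccc2Cl)c1COc1ccc(-c2nc3ccc(C(=O)O)cc3n2C)c(Cl)c1` — 3.66 nM

All three were run in an assay on Huh-7 cells for agonist activity at Bile acid receptor (Homo sapiens), read by a luciferase reporter; a higher number here means that more compound is needed for the effect, a lower number that less compound is needed. Compound 2 gives 13.6 nM, the highest number of the three. Compound 3 sits nearer to it and gives 3.66 nM, a gap beyond the scatter; compound 1 is furthest and gives 1.3 nM, also beyond the scatter. Going by the values given here, the three differ from one another at more than one place, so no single step between them can be read off.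

Compound 4 `CC(C)c1onc(-c2c(Cl)cccc2Cl)c1COc1ccc(-c2nc3ccc(C(=O)O)cc3n2CC2CCCCC2)cc1` is not yet measured. It differs from compound 2 in one place:
cyclohexylmethyl in place of cyclopentyl on an aromatic nitrogen

No measured pair in this set isolates a change of this kind on the ring nitrogen, so the expectation rests on the shown values alone. The step from compound 2 to compound 4 is estimated at a 1.7-fold lower number from compound 2 to compound 4 (0.23 log units; within the scatter), which is expected to be a small move toward a lower number, or none beyond the scatter. Compound 4 is therefore estimated at 8 nM, with a range from 2.5 nM to 30 nM.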

Compound 4, half-maximal effective concentration: 0.52 nM
Compound 4: the middle estimate sits 15-fold (1.19 log units) above what was measured; measured number below the stated range.
By their numbers in this assay, from the lowest: compound 4; then compound 1; then compound 3; then compound 2.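

In this assay, going by these compounds alone, the substituent on the aromatic nitrogen is the first place where a single change can be read, and cyclohexylmethyl in place of cyclopentyl gives a 26-fold lower number from compound 2 to compound 4 (1.42 log units; beyond the scatter), a large step. The position therefore accepts the larger group, 7 heavy atoms against 5, with the number falling rather than rising, although both groups are carbon only and carry no hydrogen-bond donors, acceptors or charge. No measurement at hand explains the size of this step.

Still open, as far as these compounds go, is whether the methylene link or the six-membered ring carries the step; cyclohexyl set directly on the nitrogen, or cyclopentylmethyl, would separate the two. Also open, from the compounds shown here alone, is whether a ring is needed at all, which a longer open chain such as hexyl could test against compound 4.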